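Ring size and methylation at the sulfonyl-indole-type core nitrogen

The source may report more compounds than this note shows. Statements on the series, on what has been measured and on what is new or still open speak of the compounds shown alone.

Compound 3 `O=S(=O)(C1=C(Cl)NC2SC=CN12)c1cn(C2CCNC2)c2ncccc12` sits at the low end of the numbers seen so far in an assay on HeLa cells for displacement of a labelled ligand from 5-hydroxytryptamine receptor 6 (Homo sapiens) (a lower number here means a stronger inhibitor, a higher number a weaker inhibitor), where compound 3 gives 1 nM. Compound 1 `O=S(=O)(c1cccc(Br)c1)c1cn(C2CCNC2)c2ncccc12` lies within the scatter of that figure, as in this assay compound 1 gives 1.3 nM. Compound 2 `CN1CCC(n2cc(S(=O)(=O)c3ccccc3Cl)c3cccnc32)C1` is the only one beyond the scatter, since in this assay compound 2 gives 2.2 nM. Between compound 3 and compound 1 no order can be read; between compound 3 and compound 2 the gap is real but modest.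

Compound 4 `CN1CCCC(n2cc(S(=O)(=O)C3=C(Cl)NC4SC=CN34)c3cccnc32)C1` has not yet been run in this assay. It differs from compound 3 in one place: 1-methylpiperidin-3-yl in place of pyrrolidin-3-yl on an aromatic nitrogen. Going by the values given here, no measured pair in the set isolates this change, so its size is open. The values of compound 1 and compound 2, which carry the unsubstituted and the methylated five-membered amine on different cores, show only a small spread between them. The step from compound 3 to compound 4 is therefore expected to be small, a 2.2-fold higher number from compound 3 to compound 4 (0.34 log units; beyond the scatter), leaning toward a slightly higher number. Compound 4 is estimated at 2.2 nM in this assay, with a likely range from 0.7 nM to 7 nM.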

Compound 4, inhibition constant: 2 nM
For compound 4 the middle estimate is 1.1-fold (0.04 log units) above the measured one; the measured number falls inside the stated range.
By their numbers in this assay, from the lowest: compounds 3, 1, 4 and 2 (each within the scatter of the next, the first and the last beyond it).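

In this assay, going by these compounds alone, 1-methylpiperidin-3-yl in place of pyrrolidin-3-yl on the aromatic nitrogen gives a 2.0-fold higher number from compound 3 to compound 4 (0.30 log units; within the scatter) and is the first step that isolates this position. On this core the position therefore takes the six-membered ring and the methyl together, and the loss of the hydrogen-bond donor of pyrrolidin-3-yl, with no difference that can be told from scatter. Within the data shown here, nothing measured so far offers an explanation for this result.

Ring size and methylation change together in this step, so their separate contributions cannot be read; piperidin-3-yl on the same core would separate them. Also open, on these data alone, is whether the aromatic nitrogen holds groups of another kind, such as a 1-benzylpiperidin-4-yl group or an open aminoethyl chain.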